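A few compounds are considered here, and "the series" means these few. Any claim that something is new, unique, unknown or untested is made for them only; others in the source may bear on it.

In a physicochemical assay for acid dissociation, compound 1 `CC(C)(C)c1ccc(Oc2ccc3c(NCCCNCc4ccco4)ccnc3c2)cc1` gives 9.28. Compound 2 `COc1ccccc1Oc1ccc2c(NCCCNCc3ccco3)ccnc2c1` gives 9.28, and compound 3 `Clc1ccc(Oc2ccc3c(NCCCNCc4ccco4)ccnc3c2)cc1` gives 9.28, so compound 1 stands level with both of them. The three steps among these compounds, no change at the digits printed from compound 1 to compound 2 (within the scatter), no change at the digits printed from compound 1 to compound 3 (within the scatter) and no change at the digits printed from compound 2 to compound 3 (within the scatter), all stay within the scatter, although each swaps the group sitting on the oxygen on an aromatic ring of the shared core. Compound 4 `COc1ccc(F)cc1CNCCCNc1ccnc2cc(Oc3ccc(C(C)(C)C)cc3)ccc12` differs from compound 1 at a different place in the molecule: 5-fluoro-2-methoxyphenyl in place of furan-2-yl on a saturated chain carbon bound to an amine nitrogen. Going by the values given here, no measured step touches that place; the measured steps show only that changing the group on the oxygen on an aromatic ring leaves the read-out where it was, while the chain and the amine nitrogen it carries stay the same in every compound. With nothing pointing either way, the step expected from compound 1 to compound 4 is a number 0.02 log units higher from compound 1 to compound 4 (within the scatter), within the scatter. Compound 4 is therefore estimated at 9.3, within a range from 8.8 to 9.8.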

Compound 4, acid dissociation constant: 9.28
For compound 4 the middle estimate is 0.02 log units above the measured one; measured number inside the range.
By their numbers in this assay, from the lowest: compounds 1, 2, 3 and 4 (each within the scatter of the next).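

In this assay, the swap of furan-2-yl for 5-fluoro-2-methoxyphenyl on a saturated chain carbon bound to an amine nitrogen gives no change at the digits printed from compound 1 to compound 4 (within the scatter), so a second place in the molecule now has a measured step. This exchange is a sizeable one by count: 5 heavy atoms leave and 9 enter, and a five-membered aromatic ring with 1 hetero atom gives way to a six-membered aromatic ring of carbon only, yet the read-out stays level. No measurement shown offers an explanation for this result. As far as these compounds go, what remains open is whether a carboxylic acid or a second amine in place of the furan-2-yl would shift the read-out. A longer chain carrying the amine nitrogen is equally open, as this chain is the same in all the compounds shown.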